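Working notes: moving the trifluoromethyl group

The source may hold more compounds than are shown below. What is called first, only, known or untested is meant among the compounds shown, and "the series" means these compounds.

Measured in a functional assay on MCF7 cells (Homo sapiens) for antiproliferative activity, read by MTT assay, with a stated time of 72 h; on this read-out higher numbers stand for weaker inhibition and lower numbers for stronger inhibition:
- compound 1 `CC1=CC[C@H]2[C@H](CC[C@]2(C)O)C(C)(C)[C@@H]1CC[C@H]1[C@]2(C)CC[C@H](OC(=O)c3ccccc3)C(C)(C)O[C@H]2CC[C@@]1(C)O`: 21000 nM
- compound 2 `CC1=CC[C@H]2[C@H](CC[C@]2(C)O)C(C)(C)[C@@H]1CC[C@H]1[C@]2(C)CC[C@H](OCc3ccccc3)C(C)(C)O[C@H]2CC[C@@]1(C)O`: > 50000 nM, a limit of the assay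
- compound 3 `CC1=CC[C@H]2[C@H](CC[C@]2(C)O)C(C)(C)[C@@H]1CC[C@H]1[C@]2(C)CC[C@H](OC(=O)c3cccc(C(F)(F)F)c3)C(C)(C)O[C@H]2CC[C@@]1(C)O`: 37900 nM

Compound 3 stands within the scatter of its nearest measured neighbour, as shown by a 1.8-fold higher number from compound 1 to compound 3 (0.26 log units; within the scatter). Against the limit, the comparison gives an at least 1.3-fold lower number from compound 2 to compound 3 (0.12 log units; that floor lies within the scatter), so it does not separate the two compounds.

Compound 4 `CC1=CC[C@H]2[C@H](CC[C@]2(C)O)C(C)(C)[C@@H]1CC[C@H]1[C@]2(C)CC[C@H](OC(=O)c3ccccc3C(F)(F)F)C(C)(C)O[C@H]2CC[C@@]1(C)O` keeps the shared core and the carbonyl link of compound 3. The change is 2-(trifluoromethyl)phenyl in place of 3-(trifluoromethyl)phenyl on a carbonyl carbon.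

For the measured compounds named here, no measured step moves the trifluoromethyl group, so the evidence is indirect. The closest guide is a 1.8-fold higher number from compound 1 to compound 3 (0.26 log units; within the scatter), where adding that group left the read-out within the scatter. Going by the values given here, the one step beyond the scatter is an at least 2.3-fold higher number from compound 1 to compound 2 (0.37 log units; beyond the scatter), which replaces benzoyl with benzyl, and compound 4 makes no such replacement. A shift of the group on the same ring is therefore not expected to produce a clear change in this assay.

The expected step is a 1.2-fold lower number from compound 3 to compound 4 (0.07 log units; within the scatter), with none expected beyond the scatter. For compound 4 the estimated value is 32000 nM, with an expected range of 15000 nM to 50000 nM.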

Compound 4, half-maximal inhibitory concentration: 19200 nM
Compound 4: the middle estimate sits 1.7-fold (0.22 log units) above what was measured, within the range that was stated.
By their numbers in this assay, from the lowest: compounds 4, 1 and 3 (each within the scatter of the next). At a limit, above all of these: compound 2.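

In this assay, moving the trifluoromethyl group on the ring attached to the carbonyl carbon, with 2-(trifluoromethyl)phenyl in place of 3-(trifluoromethyl)phenyl, gives a 2.0-fold lower number from compound 3 to compound 4 (0.30 log units; within the scatter), so this first direct comparison does not separate the two placements. Adding the group to the benzoyl ring of compound 1 in the 2-(trifluoromethyl)phenyl arrangement gives a 1.1-fold lower number from compound 1 to compound 4 (0.04 log units; within the scatter), so neither trifluoromethyl compound is separated from the unsubstituted benzoyl compound. The change from the benzyl ether gives an at least 2.6-fold lower number from compound 2 to compound 4 (0.41 log units; beyond the scatter), which makes compound 4 the first trifluoromethyl compound here to be separated from compound 2, whose reading is a limit of the assay: the limit of > 50000 nM in this assay, at which 1 of the 4 values shown sits.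

The compounds shown leave open whether a group other than trifluoromethyl on this ring, such as an amine or a carboxylic acid, would move the read-out in this assay clear of the scatter around compound 1. Also open, from the compounds shown here alone, is whether the carbonyl link would hold its place with a longer chain in place of the aromatic ring.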